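The compounds below may be only part of what the source reports. "The series", "measured", "known", "first", "only" and "open" are said of these compounds alone.

Compound 3 `CCOc1ccc(-c2ccc(N(C[C@@H](N)[C@@H](C)CC)C(=O)[C@@H]3C[C@H]3c3ccccc3)cc2)cc1` sits second highest of the three numbers in a functional assay for agonist activity at G protein-coupled receptor 88 (Homo sapiens), read by HTRF and cAMP accumulation (a higher number here means that more compound is needed for the effect, a lower number that less compound is needed), where compound 3 gives 90 nM; its nearest neighbour is compound 2 `CC[C@H](C)[C@H](N)CN(C(=O)[C@@H]1C[C@H]1c1ccccc1)c1ccc(-c2ccc(OC(C)C)cc2)cc1`, which in this assay gives 72 nM, and its furthest is compound 1 `CC[C@H](C)[C@H](N)CN(C(=O)[C@@H]1C[C@H]1c1ccccc1)c1ccc(-c2ccc(C(F)(F)F)cc2)cc1`, which in this assay gives 340 nM. The step from compound 2 to compound 3 is a 1.3-fold higher number from compound 2 to compound 3 (0.10 log units; within the scatter), while the two steps that leave the trifluoromethyl of compound 1 are larger: a 4.7-fold lower number from compound 1 to compound 2 (0.67 log units; beyond the scatter) and a 3.8-fold lower number from compound 1 to compound 3 (0.58 log units; beyond the scatter).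

Compound 4 `CC[C@H](C)[C@H](N)CN(C(=O)[C@@H]1C[C@H]1c1ccccc1)c1ccc(-c2ccc(COC(C)(C)C)cc2)cc1` differs from compound 3 by (tert-butoxy)methyl in place of ethoxy on an aromatic carbon. For the measured compounds named here, no measured step swaps one oxygen-bearing chain for another of different length; the only bearing step, from compound 2 to compound 3, stays within the scatter, so a small shift in this assay is expected, if any. For compound 4 a step of a 1.4-fold higher number from compound 3 to compound 4 (0.16 log units; within the scatter) is estimated. Compound 4 is expected to give about 130 nM in this assay, within a range from 45 nM to 400 nM.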

Compound 4, half-maximal effective concentration: 280 nM
For compound 4 the middle estimate is 2.2-fold (0.33 log units) below the measured one, and the stated range covers the measured number.
By their numbers in this assay, from the lowest: compounds 2 and 3 (each within the scatter of the next); then compounds 4 and 1 (each within the scatter of the next).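

In this assay this position turns out not to be indifferent to the oxygen-bearing group it carries: placing (tert-butoxy)methyl here gives (a 3.1-fold higher number from compound 3 to compound 4 (0.49 log units; beyond the scatter)) and (a 3.9-fold higher number from compound 2 to compound 4 (0.59 log units; beyond the scatter)), whereas ethoxy and isopropoxy could not be told apart. Against trifluoromethyl, the same group gives (a 1.2-fold lower number from compound 1 to compound 4 (0.08 log units; within the scatter)), so compound 4 shows that an oxygen in this substituent does not by itself keep the lower numbers of compound 2 and compound 3. No available evidence accounts for this shift.

Going by these compounds, it remains open whether the rise follows the methylene link or the tert-butyl end of the new group. A tert-butoxy or a methoxymethyl group at this place would separate the two, and an amine would test a different kind of substituent.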